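The compounds below may be only part of what the source reports. "The series", "measured", "known", "first", "only" and "open" are said of these compounds alone.

Measured so far in an ADME assay for permeability, using PAMPA, with a stated time of 30 min, at pH 7.4; on this read-out lower numbers stand for lower permeability and higher numbers for higher permeability:

Compound 1 `COc1ccc(-c2c(-c3ccc(OC)cc3)n(Cc3ccccc3)c3ncn([C@H]4CC[C@H](OC)CC4)c(=N)c23)cc1`: > 1000 10^-6 cm/s
Compound 2 `COc1ccc(Cn2c(-c3ccccc3)c(-c3ccccc3)c3c(=N)n(CC4CCCO4)cnc32)cc1`: > 1000 10^-6 cm/s
Compound 3 `N=c1c2c(-c3ccccc3)c(-c3ccccc3)n(Cc3ccccc3)c2ncn1CCCN1CCN(c2ccccc2)CC1`: > 1000 10^-6 cm/s

The figure for compound 1 is a limit of this assay, not a measured number. The figures for compound 2 and compound 3 are limits of the same kind. Going by the values given here, all three readings therefore sit at the same point, which is the limit of > 1000 10^-6 cm/s in this assay, at which 3 of the 3 values shown sit, and compound 1 cannot be ranked against the other two on these numbers: they show only that each compound crossed the membrane faster than this assay can resolve.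

The untested compound 4 `COc1ccc(-c2c(-c3ccc(OC)cc3)n(Cc3ccccc3)c3ncn(CCO)c(=N)c23)cc1` differs from compound 1 in one place: 2-hydroxyethyl in place of 4-methoxycyclohexyl on an aromatic nitrogen. In words, a 2-hydroxyethyl group takes the place of a 4-methoxycyclohexyl group on an aromatic nitrogen. Among the compounds with values here, no pair of measured compounds shows what such a swap does in this assay, so the expectation rests on compound 1 alone. The step from compound 1 to compound 4 is estimated as an at least 1.1-fold lower number from compound 1 to compound 4 (0.04 log units; that floor lies within the scatter), that is, within the usual scatter or at most a modest drop. Compound 4 is therefore expected to give about 900 10^-6 cm/s in this assay, in a range from 300 10^-6 cm/s to 2000 10^-6 cm/s, and quite possibly again only a limit.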

Compound 4, apparent permeability: > 1000 10^-6 cm/s
Compound 4 gave a limit, no number; the forecaster's own chance of this, stated with the estimate: 60%; middle value at least 1.1-fold (0.04 log units) away from the limit.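

Going by these compounds alone, compound 1 and compound 4 both stand at a limit of the assay rather than at a number, so no step between them can be read: the limit of > 1000 10^-6 cm/s in this assay, at which 4 of the 4 values shown sit. The compounds shown leave open how far apart any of them truly lie in this assay, and so what 2-hydroxyethyl in place of 4-methoxycyclohexyl does to the read-out.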